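From a Branched Hydroxymethyl Group to Cyclohexyl

A few compounds are considered here, and "the series" means these few. Any claim that something is new, unique, unknown or untested is made for them only; others in the source may bear on it.

In an ADME assay on microsomes (Rattus norvegicus) for metabolic stability (on this read-out lower numbers stand for a shorter-lived compound and higher numbers for a longer-lived compound), compound 1 `CC(C)C(=O)N1N=CCC1c1ccccc1` gives 1.33 h. Compound 2 `CC(C)(CO)C(=O)N1N=CCC1c1ccccc1` gives 0.917 h, so the two compounds lie within the usual scatter of each other. Among the compounds with values here, the one measured step, a 1.5-fold lower number from compound 1 to compound 2 (0.16 log units; within the scatter), put hydroxymethyl in place of hydrogen on a saturated chain carbon bound to a carbonyl carbon, and it stayed within the scatter.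

Compound 3 `O=C(C1CCCCC1)N1N=CCC1c1ccccc1` keeps the shared core but carries cyclohexyl in place of 1-(hydroxymethyl)-1-methylethyl on the carbonyl carbon: cyclohexyl in place of 1-(hydroxymethyl)-1-methylethyl on a carbonyl carbon. Within the data shown here, no measured compound has a ring in that place, so the one measured step is only a weak guide. With so little to go on, the expected step in this assay, a 1.1-fold lower number from compound 2 to compound 3 (0.06 log units; within the scatter), is no larger than the scatter, and no clear direction is expected. Compound 3 is expected at 0.8 h, with an estimated range of 0.35 h to 1.6 h.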

Compound 3, half-life: 0.0833 h
Beside the measured number, compound 3's estimate is 9.6-fold (0.98 log units) above it, outside the stated range (below it).
By their numbers in this assay, from the lowest: compound 3; then compounds 2 and 1 (each within the scatter of the next).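

The group on the carbonyl carbon turns out to matter a great deal in this assay: replacing the branched hydroxymethyl chain gives an 11-fold lower number from compound 2 to compound 3 (1.04 log units; beyond the scatter), and replacing isopropyl gives a 16-fold lower number from compound 1 to compound 3 (1.20 log units; beyond the scatter). Adding hydroxymethyl to the open chain had stayed within the scatter, so this position tolerated that change, whereas cyclohexyl is the first group here to shift the half-life beyond it. No measurement at hand explains why compound 3 is so much shorter-lived.

Going by these compounds, it remains open whether a smaller ring such as cyclopropyl, a cyclohexyl carrying a hydroxyl, or a ring containing oxygen such as tetrahydropyranyl would give an equally short half-life. The compounds shown also do not tell whether an unbranched open chain such as n-hexyl would fall as far as cyclohexyl.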